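The source may report more compounds than this note shows. Statements on the series, on what has been measured and on what is new or still open speak of the compounds shown alone.

Compound 1 `CC(C)(C)N(NC(=O)c1ccccc1Cl)C(=O)c1ccccc1Cl` gives 331 nM in an assay on cells for agonist activity at ecdysone receptor (Bombyx mori), read by a luciferase reporter, with a stated time of 24 h; on this read-out lower numbers stand for an effect already at smaller amounts and higher numbers for an effect only at larger amounts of compound. Among the compounds with values here, compound 2 `CC(C)(C)N(NC(=O)c1ccc(F)cc1)C(=O)c1ccccc1Cl` gives 389 nM in this assay, and the step of a 1.2-fold higher number from compound 1 to compound 2 (0.07 log units; within the scatter) separates the two; compound 2 thus lies within the scatter of compound 1, the only other measured compound. Compound 3 `Cc1ccc(C(=O)NN(C(=O)c2ccccc2Cl)C(C)(C)C)c(C)c1` carries the change (2,4-dimethylphenyl in place of 4-fluorophenyl on a carbonyl carbon). Within the data shown here, the only measured step on the same carbonyl carbon, a 1.2-fold higher number from compound 1 to compound 2 (0.07 log units; within the scatter), swapped one aryl group for another without a shift beyond the scatter, so for compound 3 no step beyond the scatter is expected in either direction, a 1.0-fold higher number from compound 2 to compound 3 (0.01 log units; within the scatter). Compound 3 is estimated at 400 nM, with a range from 150 nM to 1200 nM.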

Compound 3, half-maximal effective concentration: 162 nM
For compound 3 the middle estimate is 2.5-fold (0.39 log units) above the measured one; the range from low to high includes it.
By their numbers in this assay, from the lowest: compound 3; then compounds 1 and 2 (each within the scatter of the next).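

On this carbonyl carbon, the choice of aryl group can shift the read-out in this assay beyond the scatter: 2,4-dimethylphenyl gives a 2.4-fold lower number from compound 2 to compound 3 (0.38 log units; beyond the scatter) and a 2.0-fold lower number from compound 1 to compound 3 (0.31 log units; beyond the scatter). The earlier swap of 2-chlorophenyl for 4-fluorophenyl did not do so (a 1.2-fold higher number from compound 1 to compound 2 (0.07 log units; within the scatter)), and compound 3 now stands apart from both compounds, by a modest margin. No measured evidence bears on this result. From the compounds shown here alone, whether a single methyl group would carry the same step remains open. So does the outcome with a carboxylic acid or an amine on this aryl ring.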